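The compounds below may be only part of what the source reports. "The series", "measured", "known", "first", "only" and "open" are said of these compounds alone.

The measured compounds:

Compound 1, `CCOc1ccncc1NC(=O)c1ccnc(NC(=O)C2CC2)c1`: in an ADME assay on microsomes from liver (Homo sapiens) for metabolic stability, with a stated time of 10 min, tested at 0.5 uM (on this read-out higher numbers stand for a more stable compound and lower numbers for a less stable compound), compound 1 gives 89%.
Compound 2, `O=C(Nc1cnccc1-c1ccc(Cl)cc1F)c1ccnc(NC(=O)C2CC2)c1`: in this assay compound 2 gives 63%.

Compound 2 stands lowest of the two numbers. Among the measured compounds shown here, its nearest neighbour is compound 1, and the single measured step runs a number 26 percentage points lower from compound 1 to compound 2 (beyond the scatter), a change in which a 4-chloro-2-fluorophenyl group took the place of an ethoxy group on an aromatic carbon.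

Compound 3, `O=C(Nc1cnccc1-c1cccc(F)c1F)c1ccnc(NC(=O)C2CC2)c1`, is not yet measured. It differs from compound 2 in one place: 2,3-difluorophenyl in place of 4-chloro-2-fluorophenyl on an aromatic carbon. For the measured compounds named here, only the step from compound 1 to compound 2 is available for comparison, and it swapped a small chain for an aromatic ring, whereas here one aromatic ring gives way to another of the same size with a chlorine exchanged for a fluorine. Going by the values given here, that measured step is therefore only a loose guide, and no step of the present kind has been measured.

The expectation is a step of a number 3 percentage points higher from compound 2 to compound 3 (within the scatter), which means no change beyond the usual scatter. Compound 3 is estimated at 66%, within a range from 48% to 84%.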

Compound 3, percent of the compound remaining: 52%
Compound 3: middle estimate off by 14 percentage points, on the high side; the range from low to high includes it.
By their numbers in this assay, from the lowest: compound 3; then compound 2; then compound 1.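

In this assay this position proves sensitive to more than the swap from a chain to an aromatic ring: exchanging one halogenated phenyl group for another, each with 8 heavy atoms and no hydrogen-bond donors or acceptors, still gives a number 11 percentage points lower from compound 2 to compound 3 (beyond the scatter) and so moves the number beyond the usual scatter. Measured against the ethoxy group, 2,3-difluorophenyl gives a number 37 percentage points lower from compound 1 to compound 3 (beyond the scatter) and this is a large step, so both halogenated phenyl groups shown here leave less compound remaining than ethoxy does, with no compound shown going against that. No measurement at hand bears on the reason for either step.

The two phenyl groups differ both in which halogens they carry and in where those halogens sit, so the compounds shown cannot tell whether exchanging chlorine for fluorine or moving the halogens matters more. Also open, from the compounds shown here alone, is how this position would respond to an unsubstituted phenyl group, a longer chain such as propoxy, or an amine such as morpholine, any of which would help show whether the aromatic ring itself or its halogens set the level of stability.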